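Methyl on an aromatic hydroxy oxygen: compound 3

The source may hold more compounds than are shown below. What is called first, only, known or untested is meant among the compounds shown, and "the series" means these compounds.

Compound 1 `Oc1ccc(/C=C/c2cccc(O)c2)cc1` carries a hydroxy group on each of its two aromatic rings. In an assay on HEK293 cells for antagonist activity at transient receptor potential cation channel subfamily V member 1 (Homo sapiens), read by calcium flux (on this read-out lower numbers stand for stronger inhibition and higher numbers for weaker inhibition), compound 1 gives > 10000 nM, which is a limit of the assay and not a number. Compound 2 `Oc1cccc(/C=C/c2ccccc2)c1` lacks one of those hydroxy groups. In this assay compound 2 gives > 10000 nM, again a limit rather than a number. The step that the two limits leave unreadable from compound 1 to compound 2 cannot be sized, since the limit of > 10000 nM in this assay, at which 2 of the 2 values shown sit, and nothing separates the two. Compound 1 therefore stands only at that limit, with no number to set it against.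

Compound 3 `COc1cccc(/C=C/c2ccc(O)cc2)c1` differs from compound 1 by methyl in place of hydrogen on an oxygen on an aromatic ring. Among the compounds with values here, no measured step bears on a methyl entering on that oxygen, and the single measured step, from compound 1 to compound 2, is itself unreadable. The change from hydroxy to methoxy thus has no measured size in this series.

Compound 3 is expected at 15000 nM, with a range from 4000 nM to 60000 nM, most probably reported once more as a limit. The expected step that the limit leaves unreadable from compound 1 to compound 3 is accordingly not readable beyond that limit.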

Compound 3, half-maximal inhibitory concentration: > 10000 nM
Compound 3 was reported as a limit; the forecaster's own chance of this, stated with the estimate: 80%; the middle value does not contradict the limit.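

Compound 3 gives > 10000 nM in this assay, which is a limit of the assay and not a number. No step from compound 1 to compound 3 can be read, because both stand at the same limit: the limit of > 10000 nM in this assay, at which 3 of the 3 values shown sit.

The compounds shown leave open what size, if any, the change from hydroxy to methoxy has on inhibition.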